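Swapping the aryl group on the branched amine arm

The compounds below may be only part of what the source reports. "The series", "measured", "known", "first", "only" and "open" are said of these compounds alone.

Compound 1 `CCCOc1ccc(CN(Cc2ccc(C(C)(C)C)cc2)Cc2cc3cc(C)ccc3[nH]c2=O)cc1` is reported in a toxicity assay on MDCK cells (Canis lupus familiaris) for cytotoxicity, read by crystal violet staining, with a stated time of 48 h (on this read-out lower numbers stand for higher toxicity in this test and higher numbers for lower toxicity in this test), only as a limit, > 5000 nM.
Compound 2 `Cc1ccc2[nH]c(=O)c(CN(Cc3ccc(OC(F)(F)F)cc3)Cc3ccc(C(C)(C)C)cc3)cc2c1` is reported in this assay only as a limit, > 5000 nM.
Compound 3 `Cc1ccc2[nH]c(=O)c(CN(Cc3ccc(C(C)(C)C)cc3)C(C)c3ccc(F)cc3)cc2c1` is reported in this assay only as a limit, > 33000 nM.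

Compound 3 thus stands at the limit of > 33000 nM in this assay, at which 1 of the 3 values shown sits, while the other two sit at the limit of > 5000 nM in this assay, at which 2 of the 3 values shown sit; none of the three gives an actual number. Compound 4 `COc1ccc(C(C)N(Cc2ccc(C(C)(C)C)cc2)Cc2cc3cc(C)ccc3[nH]c2=O)cc1Cl` differs from compound 3 by 3-chloro-4-methoxyphenyl in place of 4-fluorophenyl on a saturated chain carbon bound to an amine nitrogen and a saturated chain carbon. The measured steps that change the group on the amine nitrogen are a step that the two limits leave unreadable from compound 1 to compound 3 and a step that the two limits leave unreadable from compound 2 to compound 3; both stay hidden behind limits, so no size can be read from them. With nothing in the three values pointing toward measurable toxicity, compound 4 is expected to remain beyond the reach of this assay as well, an expected step of about an at least 1.3-fold lower number from compound 3 to compound 4 (0.12 log units; that floor lies within the scatter). The estimate for compound 4 is 25000 nM, within an expected range from 6000 nM to 80000 nM.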

Compound 4, half-maximal cytotoxic concentration: > 10000 nM
Compound 4 was reported as a limit (the forecaster's own chance of this, stated with the estimate: 70%); the middle value does not contradict the limit.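

For the compounds shown here, no step from compound 1, compound 2 or compound 3 to compound 4 can be read in this assay: all four are reported only as limits. Going by these compounds, whether changing the group on the amine nitrogen shifts the actual number remains open.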